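This account rests on a few compounds, and the source may have more. Where it says the series, first, only, none or still open, it means among the compounds named here.

Measured compounds:
- compound 1, `CCCCc1nc(=O)c(S(=O)(=O)c2ccc(-c3ccc(F)nc3)cc2)c(O)n1-c1c(OC)cccc1OC`: 69%
- compound 2, `CCCCc1nc(=O)c(S(=O)(=O)c2ccc(-n3cc(Cl)ccc3=O)cc2)c(O)n1-c1c(OC)cccc1OC`: 100%
- compound 3, `CCCCc1[nH]c(=O)c(S(=O)(=O)c2ccc(-c3ccncc3C)cc2)c(O)c1-c1c(OC)cccc1OC`: 39%

In an ADME assay on microsomes from liver (Mus musculus) for metabolic stability, using NADPH, with a stated time of 10 min (a higher number here means that more of the compound is left, a lower number that less of the compound is left), compound 3 gives 39%, the lowest of the three numbers. Compound 1 gives 69% and compound 2 gives 100%, both beyond the scatter above compound 3. Compound 3 also has a core that differs from the shared core of compounds 1 and 2, so comparisons across that divide are loose.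

Compound 4, `CCCCc1[nH]c(=O)c(S(=O)(=O)c2ccc(-n3ccccc3=O)cc2)c(O)c1-c1c(OC)cccc1OC`, is not yet measured. It differs from compound 3 in one place: a group of 7 heavy atoms (5 carbon, 1 nitrogen, 1 oxygen; one six-membered aromatic ring with 1 hetero atom) in place of a group of 7 heavy atoms (6 carbon, 1 nitrogen; one six-membered aromatic ring with 1 hetero atom), on an aromatic carbon. Going by the values given here, the only measured step that bears on this is the one from compound 1 to compound 2, where a pyridinone-type ring likewise replaced a pyridine ring on the same aromatic carbon, with a number 31 percentage points higher from compound 1 to compound 2 (beyond the scatter). The leaving and entering groups there carried different small substituents than here, and the core was different, so the match is not exact.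

On that single step, the expectation for this assay is an increase in the amount of compound remaining, of a size roughly like the step from compound 1 to compound 2, giving an expected step of a number 26 percentage points higher from compound 3 to compound 4 (beyond the scatter). Compound 4 is therefore estimated at 65%, with a range from 45% to 90%.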

Compound 4, percent of the compound remaining: 75%
Compound 4: the middle estimate sits 10 percentage points below what was measured; the range from low to high includes it.
By their numbers in this assay, from the lowest: compound 3; then compounds 1 and 4 (each within the scatter of the next); then compound 2.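

In this assay, the change at this place, on an aromatic carbon para to a large group, gives a number 36 percentage points higher from compound 3 to compound 4 (beyond the scatter), so the large rise seen earlier, a number 31 percentage points higher from compound 1 to compound 2 (beyond the scatter), now appears on a second core as well. The rise also holds with a different leaving group, 3-methylpyridin-4-yl, and with an entering pyridinone-type ring that carries no chlorine, so chlorine on that ring is not needed for a step of this kind among these compounds, and neither listed step goes against the pattern. No measurement shown here accounts for why more of the compound remains after this swap.

Each step changes several features at once, including the ring's point of attachment, its carbonyl oxygen and, in the step from the pyridine ring, the methyl group, so the compounds shown cannot say which of these features goes with the higher number. As far as these compounds go, it also remains open how this assay would respond to a group of a different kind at the same place, such as a morpholine ring, a carboxylic acid or a simple open-chain amide.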